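The compounds below may be only part of what the source reports. "The series", "measured", "known", "first", "only" and "open" are said of these compounds alone.

In an ADME assay on HepG2 cells (Homo sapiens) for cytotoxicity, read by MTT assay, with a stated time of 72 h (on this read-out higher numbers stand for lower toxicity in this test and lower numbers for higher toxicity in this test), compound 1 `CC1(Cc2ccccc2)CC(S(=O)(=O)c2cccc(C(F)(F)F)c2)=C(c2ccc(/C(N)=N\O)cc2)O1` gives 33400 nM. That is the higher of the two exact numbers available, and the gap lies beyond the usual scatter, since compound 2 `CC1(c2ccc(-c3ccc(/C(N)=N\O)cc3)cc2)CC(S(=O)(=O)c2ccc(F)cc2)=C(c2ccc(/C(N)=N\O)cc2)O1` gives 15300 nM. Compound 3 `CC1(c2ccc(-c3cccc([N+](=O)[O-])c3)cc2)CC(S(=O)(=O)c2ccc(F)cc2)=C(c2ccc(/C(N)=N\O)cc2)O1` gives > 50000 nM, which is a limit of the assay and not a number.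

Compound 4 `CC1(Cc2ccccc2)CC(S(=O)(=O)c2ccccc2C(F)(F)F)=C(c2ccc(/C(N)=N\O)cc2)O1` differs from compound 1 in one place: 2-(trifluoromethyl)phenyl in place of 3-(trifluoromethyl)phenyl on a sulfonyl sulfur. The two have the same atoms, joined differently, with 2-(trifluoromethyl)phenyl in place of 3-(trifluoromethyl)phenyl on a sulfonyl sulfur.

For the measured compounds named here, only one measured step exists, an at least 3.2-fold higher number from compound 2 to compound 3 (0.51 log units; beyond the scatter). It shows that numbers in this assay can move, but it exchanges other groups on an aromatic carbon, so it bears on this swap only weakly. Going by the values given here, no measured step moves a trifluoromethyl group. The best guide is therefore compound 1 itself, at 33400 nM, and no change beyond the scatter is expected. The expected step is a 1.0-fold lower number from compound 1 to compound 4 (0.01 log units; within the scatter). Compound 4 is estimated at 33000 nM, with an expected range of 17000 nM to 50000 nM.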

Compound 4, half-maximal cytotoxic concentration: 57500 nM
For compound 4 the middle estimate is 1.7-fold (0.24 log units) below the measured one; measured number outside the range, above it.
By their numbers in this assay, from the lowest: compound 2; then compounds 1 and 4 (each within the scatter of the next).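

Replacing 3-(trifluoromethyl)phenyl with 2-(trifluoromethyl)phenyl on a sulfonyl sulfur gives a 1.7-fold higher number from compound 1 to compound 4 (0.24 log units; within the scatter). For the compounds shown here, this is the first measured step at this position, and in this assay it shows that moving the trifluoromethyl group on this ring leaves the two compounds indistinguishable, whereas the earlier step concerned a different group on an aromatic carbon. No measurement shown bears on why this pair behaves as it does.

Still open, on these data alone, is how 4-(trifluoromethyl)phenyl on the same sulfonyl sulfur would compare with these two compounds. Also unknown is whether a ring carrying an amine or a carboxylic acid in place of trifluoromethyl would move the number beyond the scatter.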